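The source may report more compounds than this note shows. Statements on the series, on what has been measured and on what is new or still open speak of the compounds shown alone.

In a functional assay on FM3A cells (Mus musculus) for antiproliferative activity, read by cell counting, with a stated time of 2 days (a lower number here means a stronger inhibitor, a higher number a weaker inhibitor), compound 1 `COc1ccc(Nc2nc(N)c(C(=O)c3ccc(OC)c(OC)c3)s2)cc1` gives 71 nM. Compound 2 `COc1ccc(Nc2nc(N)c(C(=O)c3cc(OC)c(OC)c(OC)c3)s2)cc1` differs from it in one place, (methoxy in place of hydrogen on an aromatic carbon), and in this assay compound 2 gives 2200 nM; the change makes a 31-fold higher number from compound 1 to compound 2 (1.49 log units; beyond the scatter).

Compound 3 `Nc1nc(Nc2ccc(F)cc2)sc1C(=O)c1ccccc1` has a different core, and the difference between the two cores is not broken down here. For compound 3 only a limit is known in this assay, > 10000 nM, which is the limit of > 10000 nM in this assay, at which 1 of the 3 values shown sits.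

Compound 4 `COc1ccc(C(=O)c2sc(Nc3ccc(F)cc3)nc2N)cc1` has not yet been measured. It differs from compound 3 by methoxy in place of hydrogen on an aromatic carbon. For the measured compounds named here, this is the same kind of change as the one from compound 1 to compound 2, though the surroundings of the place differ: in compound 2 the new group sits ortho to a methoxy group, meta to a large group and meta to a methoxy group, whereas in compound 4 it sits para to a large group. Going by the values given here, because the only measured example of this kind of change, a 31-fold higher number from compound 1 to compound 2 (1.49 log units; beyond the scatter), was made in a ring already carrying two methoxy groups, it gives little direct guidance for a ring that carries none. Given that compound 3 shows only a limit, the expected step from compound 3 to compound 4 in this assay is estimated as an at least 3.3-fold lower number from compound 3 to compound 4 (0.52 log units; beyond the scatter). For compound 4 a value around 3000 nM is expected, most likely between 500 nM and 10000 nM.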

Compound 4, half-maximal inhibitory concentration: > 10000 nM
Compound 4 ended at the assay's limit; the forecaster's own chance of this, stated with the estimate: 35%; at least 3.3-fold (0.52 log units) between middle value and limit.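

In this assay compound 3 and compound 4 both stand at a limit rather than at a number, so the step between them cannot be read: the limit of > 10000 nM in this assay, at which 2 of the 4 values shown sit.

The compounds shown leave open how strong compound 3 and compound 4 really are, and so whether going from phenyl to 4-methoxyphenyl changes the activity in either direction.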